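Chloro in Place of Methyl on a Shared Core

The source may report more compounds than this note shows. Statements on the series, on what has been measured and on what is new or still open speak of the compounds shown alone.

Compound 1 `Cc1ccc2oc(-c3c4c(N)n[nH]c(=O)c4nn3-c3ccc(NC(=O)/C=C/CN(C)C)cc3)c(C)c2c1` in a functional assay on KG-1 cells (Homo sapiens) for antiproliferative activity, read by CCK-8 assay, with a stated time of 72 h (a lower number here means a stronger inhibitor, a higher number a weaker inhibitor), gives < 0.3 nM, a limit of the assay.
Compound 2 `C=CC(=O)Nc1ccc(-n2nc3c(=O)[nH]nc(N)c3c2-c2oc3ccc(C)cc3c2C)cc1` gives < 0.3 nM, also a limit.
Compound 3 `C=CC(=O)NCc1ccc(-n2nc3c(=O)[nH]nc(N)c3c2-c2oc3ccc(C)cc3c2C)cc1` gives 0.6 nM.

Compound 2 stands at the floor of what this assay can report. Its value is a limit and not a number, so it can only be said that compound 2 is at least as strong as that limit. Compound 1 sits at the same limit. Among the measured compounds shown here, compound 3 is the one compound with a numerical value; the step from compound 2 to it, an at least 2.0-fold higher number from compound 2 to compound 3 (0.30 log units; that floor lies within the scatter), has a floor that lies within the scatter, as does an at least 2.0-fold higher number from compound 1 to compound 3 (0.30 log units; that floor lies within the scatter), while a step that the two limits leave unreadable from compound 1 to compound 2 cannot be read at all (the limit of < 0.3 nM in this assay, at which 2 of the 3 values shown sit).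

Compound 4 `C=CC(=O)Nc1ccc(-n2nc3c(=O)[nH]nc(N)c3c2-c2oc3ccc(Cl)cc3c2C)cc1` differs from compound 2 by a single atom swap: chloro in place of methyl on an aromatic carbon. For the measured compounds named here, none of the measured steps touches this position; all three concern the amide side of the molecule. Going by the values given here, no measured step therefore bears on the change, and no step beyond the scatter is expected. Compound 4 is estimated at 0.3 nM, within 0.1 nM to 1 nM, so the expected step of a number no lower from compound 2 to compound 4 (the limit leaves the size open) is essentially none, and the assay is more likely than not to report only a limit again.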

Compound 4, half-maximal inhibitory concentration in the KG-1 assay: < 0.3 nM
Compound 4 ended at the assay's limit (the forecaster's own chance of this, stated with the estimate: 55%); the middle value sits exactly at the limit.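

The step from compound 2 to compound 4 in the KG-1 assay cannot be read, as the value of each compound is a limit and not a number: the limit of < 0.3 nM in the KG-1 assay, at which 3 of the 4 values shown sit.

In a physicochemical assay for solubility, read by nephelometry, in phosphate buffer, measured as kinetic solubility, at pH 7.4 (on this read-out higher numbers stand for higher solubility and lower numbers for lower solubility), compound 2 gives 20000 nM and compound 4 gives 20000 nM. From the compounds shown here alone, how compound 1, compound 2 and compound 4 truly rank in the KG-1 assay stays open.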